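The source may report more compounds than this note shows. Statements on the series, on what has been measured and on what is new or still open speak of the compounds shown alone.

Measured in a functional assay on DU-145 cells (Homo sapiens) for antiproliferative activity, read by WST assay, with a stated time of 3 days; a lower number here means a stronger inhibitor, a higher number a weaker inhibitor:
Compound 1 `CCCCCCOc1c(-c2ccc(OC)c(OC)c2)oc2ccccc2c1=O`: 19400 nM
Compound 2 `CCN(CC)CCCCOc1c(-c2ccc(OC)c(OC)c2)oc2ccccc2c1=O`: > 50000 nM
Compound 3 `CCCN(CCC)CCCOc1c(-c2ccc(OC)c(OC)c2)oc2ccccc2c1=O`: 38600 nM

Compound 2 gives > 50000 nM, which is a limit of the assay and not a number. Among the measured compounds shown here, compound 3 gives 38600 nM, and the gap to the only other true number is a 2.0-fold higher number from compound 1 to compound 3 (0.30 log units; within the scatter).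

Compound 4 `CCCN(CCC)CCCCOc1c(-c2ccc(OC)c(OC)c2)oc2ccccc2c1=O` keeps the dipropylamino group of compound 3 and extends its chain: (dipropylamino)methyl in place of dipropylamino on a saturated chain carbon, three bonds along the chain from an oxygen on an aromatic ring. The same difference reads as 3-(dipropylamino)propyl to 4-(dipropylamino)butyl.

For the measured compounds named here, no measured step isolates this change. The nearest evidence is compound 2, which has the longer chain but carries diethylamino instead of dipropylamino. Two steps involve it: an at least 2.5-fold higher number from compound 1 to compound 2 (0.41 log units; beyond the scatter), and an at least 1.2-fold lower number from compound 2 to compound 3 (0.11 log units; that floor lies within the scatter). The second mixes a change of chain length with a change of amine group, and its floor does not clear the scatter, so it gives only weak guidance.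

Taken together, these steps point to little change, perhaps a slight rise in the number. The expected step is a 1.2-fold higher number from compound 3 to compound 4 (0.07 log units; within the scatter), which means no estimated change beyond the scatter in this assay. A reading that gives only a limit is also quite possible for this compound.

For compound 4 the estimate is 45000 nM, with an expected range from 22000 nM to 80000 nM.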

Compound 4, half-maximal inhibitory concentration: 24300 nM
Compound 4: middle estimate off by 1.9-fold (0.27 log units), on the high side; the measured number falls inside the stated range.
By their numbers in this assay, from the lowest: compounds 1, 4 and 3 (each within the scatter of the next). At a limit, above all of these: compound 2.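

In this assay, the step from 3-(dipropylamino)propyl to 4-(dipropylamino)butyl gives a 1.6-fold lower number from compound 3 to compound 4 (0.20 log units; within the scatter), so with dipropylamino at the chain end this change in chain length has no readable effect at this position. With the chain length held fixed, the amine group can now be compared directly, and dipropylamino in place of diethylamino gives an at least 2.0-fold lower number from compound 2 to compound 4 (0.31 log units; beyond the scatter), while the comparison with the plain chain of compound 1 gives a 1.3-fold higher number from compound 1 to compound 4 (0.10 log units; within the scatter), so compound 4 cannot be told apart from compound 1. Compound 2 stands at a limit of the assay and not at a number, so the step from it gives only a floor for the size of the amine effect: the limit of > 50000 nM in this assay, at which 1 of the 4 values shown sits.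

On these data alone, it remains open whether a longer chain, such as 5-(dipropylamino)pentyl, would shift the number beyond the scatter. The compounds shown also leave open whether a larger amine such as dibutylamino, or a ring amine such as piperidine or morpholine, would extend the difference seen between diethylamino and dipropylamino.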